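This account rests on a few compounds, and the source may have more. Where it says the series, first, only, none or still open, it means among the compounds named here.

Series notes. In a functional assay on HL-60 cells (Homo sapiens) for inhibition, read by CCK-8 assay, with a stated time of 48 h (on this read-out higher numbers stand for weaker inhibition and lower numbers for stronger inhibition), compound 2 `O=[N+]([O-])c1ccc(NC(=S)NCCNS(=O)(=O)c2ccc(-c3ccccc3OCc3ccccc3)s2)cc1` gives only a limit, > 50000 nM. Compound 1 `O=[N+]([O-])c1ccc(NC(=S)NCCNS(=O)(=O)c2ccc(-c3ccccc3O[C@H]3CC[C@@H](O)CC3)s2)cc1` likewise gives only a limit, > 50000 nM. Compound 3 `O=[N+]([O-])c1ccc(NC(=S)NCCNS(=O)(=O)c2ccc(-c3ccccc3O[C@H]3CC[C@H](O)CC3)s2)cc1` gives 11600 nM, so the readable steps are an at least 4.3-fold lower number from compound 2 to compound 3 (0.63 log units; beyond the scatter) and an at least 4.3-fold lower number from compound 1 to compound 3 (0.63 log units; beyond the scatter), whereas there is a step that the two limits leave unreadable from compound 1 to compound 2. Compound 2 thus stands at the limit alongside compound 1, and only compound 3 returns a number. Compound 4 `COc1ccc(NC(=O)NCCNS(=O)(=O)c2ccc(-c3ccccc3OCc3ccccc3)s2)cc1` differs from compound 2 by a group of 11 heavy atoms (8 carbon, 1 nitrogen, 2 oxygen; one six-membered aromatic ring of carbon only) in place of a group of 12 heavy atoms (7 carbon, 2 nitrogen, 2 oxygen, 1 sulfur; one six-membered aromatic ring of carbon only), on an amine nitrogen. Within the data shown here, no measured step touches this part of the molecule; the readable steps concern the group on the aromatic oxygen, which compound 4 carries unchanged from compound 2. Because compound 2 sits at the limit of > 50000 nM in this assay, at which 2 of the 3 values shown sit, the expected step of a number no higher from compound 2 to compound 4 (the limit leaves the size open) cannot be read in direction. Compound 4 is therefore estimated at about 50000 nM, with a range of 12000 nM to 150000 nM, and most likely again only a limit.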

Compound 4, half-maximal inhibitory concentration: > 50000 nM
Compound 4 was reported as a limit (the forecaster's own chance of this, stated with the estimate: 65%); the middle value sits exactly at the limit.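

No step can be read from compound 2 to compound 4, as both return only a limit: the limit of > 50000 nM in this assay, at which 3 of the 4 values shown sit.

The compounds shown leave open whether (4-methoxyphenyl)carbamoyl on the amine nitrogen shifts inhibition at all, and in which direction.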